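Replacing the Aromatic Bicycle on Compound 1

A few compounds are considered here, and "the series" means these few. Any claim that something is new, unique, unknown or untested is made for them only; others in the source may bear on it.

Of the compounds shown here, two have been measured in a physicochemical assay for solubility, in phosphate buffer, at pH 7.4; on this read-out lower numbers stand for lower solubility and higher numbers for higher solubility. Compound 1, `CC(=O)N[C@@H]1CCC[C@H](C(=O)Nc2cc(-c3nnn4ccccc34)c(Cl)cn2)C1`, gives 530000 nM in this assay, the highest of the two numbers. Compound 2, `CC(=O)N[C@@H]1CCC[C@H](C(=O)Nc2cc(-c3cnn4c3CC(C)(C)CC4)c(F)cn2)C1`, gives 160000 nM, a lower number that lies beyond the usual scatter; it differs from compound 1 in more than one place, so no single step can be read from the pair.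

Compound 3, `CC(=O)N[C@@H]1CCC[C@H](C(=O)Nc2cc(-c3cnn4c3CC(C)(C)C4)c(Cl)cn2)C1`, has not yet been measured. It differs from compound 1 by one change: a group of 10 heavy atoms (8 carbon, 2 nitrogen; one five-membered non-aromatic ring with 1 hetero atom, one five-membered aromatic ring with 2 hetero atoms) in place of a group of 9 heavy atoms (6 carbon, 3 nitrogen; one five-membered aromatic ring with 3 hetero atoms, one six-membered aromatic ring with 1 hetero atom), on an aromatic carbon. For the measured compounds named here, the group that enters keeps the chloro group of compound 1 but brings a partly saturated bicycle in the spot where compound 1 carries a fully aromatic one, and that partly saturated bicycle resembles the one carried by compound 2.

Going by the values given here, with no single-change step in this assay to lean on, the expectation for compound 3 rests on the two values shown. Compound 3 is expected to land between them, nearer to compound 2, so the step from compound 1 to compound 3 is estimated as a drop of a 2.7-fold lower number from compound 1 to compound 3 (0.42 log units; beyond the scatter), beyond the scatter. The estimated value for compound 3 in this assay is 200000 nM, with a likely range from 80000 nM to 500000 nM.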

Compound 3, solubility: 150000 nM
Compound 3: middle estimate off by 1.3-fold (0.12 log units), on the high side; the measured number falls inside the stated range.
By their numbers in this assay, from the lowest: compounds 3 and 2 (each within the scatter of the next); then compound 1.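

In this assay, this position now has its first single-change reading. With the chloro group and the rest of the core held fixed, placing a partly saturated bicycle (one five-membered non-aromatic ring with 1 hetero atom, one five-membered aromatic ring with 2 hetero atoms) on the aromatic carbon ortho to the chloro group, in place of a fully aromatic bicycle (one five-membered aromatic ring with 3 hetero atoms, one six-membered aromatic ring with 1 hetero atom), gives a 3.5-fold lower number from compound 1 to compound 3 (0.55 log units; beyond the scatter). Compound 2 differs from compound 1 in more than one place, so only this new step ties a drop beyond the scatter to the bicycle alone, and no measurement shown here speaks to why the number moves.

This single swap changes the ring saturation, the ring sizes and the nitrogen count together, so it cannot show which of these differences matters. Also open, going by these compounds, is how other groups at this position would read out, such as a plain phenyl ring or a bicycle carrying an amine or a carboxylic acid.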